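A few compounds are considered here, and "the series" means these few. Any claim that something is new, unique, unknown or untested is made for them only; others in the source may bear on it.

Three compounds have been measured in a physicochemical assay for solubility, read by HPLC, in phosphate buffer, measured as kinetic solubility, at pH 7.4; on this read-out higher numbers stand for higher solubility and lower numbers for lower solubility:

compound 1, `CCOC(=O)c1cc(-c2ccc(Cl)cc2)n(-c2ccc(S(N)(=O)=O)cc2)c1C`, gives 4200 nM
compound 2, `CCOC(=O)c1cc(-c2ccc(F)cc2)n(-c2ccc(S(N)(=O)=O)cc2)c1C`, gives 12600 nM
compound 3, `CCC(=O)c1cc(-c2ccc(F)cc2)n(-c2ccc(S(N)(=O)=O)cc2)n1`, gives 88900 nM

Compound 1 and compound 2 share one core and differ in a single place: chloro in place of fluoro on an aromatic carbon. That change produced a 3.0-fold lower number from compound 2 to compound 1 (0.48 log units; beyond the scatter). Compound 3 sits on a different core; the difference between the two cores is not broken down here. Among the three numbers, compound 3 has the highest, and its gaps to compound 2 and to compound 1 both lie beyond the scatter of repeated measurements.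

Compound 4, `CCC(=O)c1cc(-c2ccc(Cl)cc2)n(-c2ccc(S(N)(=O)=O)cc2)n1`, has not yet been measured in this assay. Within the data shown here, it differs from compound 3 by chloro in place of fluoro on an aromatic carbon, the same change, at the same place, as the one between compound 2 and compound 1, only carried out on the core of compound 3. The expectation for compound 4 rests on that single earlier step, a 3.0-fold lower number from compound 2 to compound 1 (0.48 log units; beyond the scatter), seen on the core of compound 1. With one precedent only, the range is kept wide. If the change behaves the same way here, the expected step is a 3.0-fold lower number from compound 3 to compound 4 (0.47 log units; beyond the scatter). Compound 4 is therefore estimated at 30000 nM, with the likely span running from 12000 nM to 70000 nM.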

Compound 4, solubility: 37800 nM
The estimate for compound 4 lay 1.3-fold (0.10 log units) below the measured number; the measured number falls inside the stated range.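

In this assay, putting chloro in place of fluoro on the aromatic carbon gave a 2.4-fold lower number from compound 3 to compound 4 (0.37 log units; beyond the scatter), and on the core of compound 1 the same change gave a 3.0-fold lower number from compound 2 to compound 1 (0.48 log units; beyond the scatter). Among these compounds, the change therefore carried from one core to the other with its direction intact, and each step lies beyond the scatter of repeated measurements, but these are only two matched pairs on two cores, which is too little to make it a rule for the whole series. Nothing shown here explains why the number falls on either core, and no separate measurement bears on the cause.

Among the compounds shown, only fluoro and chloro appear at this place, para to a large group, so it remains open how a bromo, a methyl, a methoxy or an amine there would compare in this assay. From the compounds shown here alone, it also remains open whether the same step would appear on a third core, or whether a carboxylic acid or a longer chain elsewhere on these molecules would change its size or direction.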